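From thiophen-2-yl to 4-methoxybenzyl on a shared core

The source may report more compounds than this note shows. Statements on the series, on what has been measured and on what is new or still open speak of the compounds shown alone.

Measured so far in an ADME assay on HEK-293T cells (Homo sapiens) for inhibition, read by CCK-8 assay, with a stated time of 48 h; on this read-out higher numbers stand for weaker inhibition and lower numbers for stronger inhibition:
- compound 1 `COc1ccc(S(=O)(=O)Oc2ccccc2/C=C(\C#N)C(=O)Nc2nnc(-c3cccs3)s2)cc1` gives (> 20000 nM)
- compound 2 `Cc1ccc(S(=O)(=O)Oc2cccc(/C=C(\C#N)C(=O)Nc3nnc(C)s3)c2)cc1` gives (> 50000 nM)

Compound 1 stands at a limit of this assay, not at a number (> 20000 nM). Compound 2 also reports only a limit (> 50000 nM). Compound 3 `COc1ccc(Cc2nnc(NC(=O)/C(C#N)=C/c3ccccc3OS(=O)(=O)c3ccc(OC)cc3)s2)cc1` has the core of compound 1, with 4-methoxybenzyl in place of thiophen-2-yl on an aromatic carbon. Going by the values given here, no measured step shows the size of such a change. No shift beyond the scatter is expected, and the estimated step is small (a step that the limit leaves unreadable from compound 1 to compound 3). For compound 3 the estimated value is 30000 nM, with an expected range from 12000 nM to 80000 nM.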

Compound 3, half-maximal inhibitory concentration: > 50000 nM
Compound 3 ended at the assay's limit; the forecaster's own chance of this, stated with the estimate: 70%; middle value at least 1.6-fold (0.22 log units) away from the limit.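

Compound 1 and compound 3 both stand at limits of this assay, so the step between them cannot be read. The compounds shown leave open what size of change, if any, 4-methoxybenzyl in place of thiophen-2-yl brings.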